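Trifluoromethyl removal on the fused core and cytotoxicity

This account rests on a few compounds, and the source may have more. Where it says the series, first, only, none or still open, it means among the compounds named here.

Compound 1 `O=[N+]([O-])C1=CNc2nc(C(F)(F)F)nn2C1c1ccc(O)c(O)c1` and compound 2 `O=[N+]([O-])C1=CNc2nc(C(F)(F)F)nn2C1c1c(O)cc(O)cc1O` carry the same fused core and differ in the pendant hydroxylated ring; the difference between the two cores is not broken down here. In an ADME assay on MDCK cells (Canis lupus familiaris) for cytotoxicity (on this read-out higher numbers stand for lower toxicity in this test and lower numbers for higher toxicity in this test), compound 1 gives 1210000 nM. In this assay compound 2 gives 838000 nM, and the two numbers of compound 1 and compound 2 lie within the usual scatter of each other, so no order is read from them.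

Compound 3 `O=[N+]([O-])C1=CNc2ncnn2C1c1c(O)cc(O)cc1O` is derived from compound 2 by the change (hydrogen in place of trifluoromethyl on an aromatic carbon). In this assay compound 3 gives > 1030000 nM, which is a limit of the assay and not a number, namely (the limit of > 1030000 nM in this assay, at which 1 of the 3 values shown sits). The step is therefore only a floor: an at least 1.2-fold higher number from compound 2 to compound 3 (0.08 log units; that floor lies within the scatter).

Compound 4 `O=[N+]([O-])C1=CNc2ncnn2C1c1ccc(O)c(O)c1` is not yet measured. Among the measured compounds shown here, it is derived from compound 1 by hydrogen in place of trifluoromethyl on an aromatic carbon, and the place line of this change is identical word for word to the one from compound 2 to compound 3, so it is the same change applied on the other pendant ring. Since the measured example of this change gave an at least 1.2-fold higher number from compound 2 to compound 3 (0.08 log units; that floor lies within the scatter) and compound 1 already sits at 1210000 nM, the expected step is a 1.2-fold higher number from compound 1 to compound 4 (0.09 log units; within the scatter). Compound 4 is estimated at 1500000 nM in this assay, with a range from 700000 nM to 3000000 nM, and a sizable chance that only a limit is returned.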

Compound 4, half-maximal cytotoxic concentration: 368000 nM
Compound 4: the middle estimate sits 4.1-fold (0.61 log units) above what was measured; the whole stated range lies above it.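

In this assay the swap of trifluoromethyl for hydrogen gives a 3.3-fold lower number from compound 1 to compound 4 (0.52 log units; beyond the scatter), so a result from one parent compound cannot be assumed to hold on the other, as the two steps for this same change differ: the same change on two cores in this assay, an at least 1.2-fold higher number (0.08 log units; that floor lies within the scatter) from compound 2 to compound 3 and a 3.3-fold lower number (0.52 log units; beyond the scatter) from compound 1 to compound 4, at least 4.0-fold (0.60 log units) apart, beyond the scatter of two such steps

Compound 3 sits at a limit of the assay and not a number, so the step on that side is known only as a floor: the limit of > 1030000 nM in this assay, at which 1 of the 4 values shown sits.

These two pairs show that the outcome of the change differs between the parent compound with the pendant ring of compound 1 and the one with the pendant ring of compound 2, but they do not give the true size of the step to compound 3, do not explain the difference, and set no rule for any further core in the series.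

Going by these compounds, it remains open how the read-out responds when the aromatic carbon between two ring nitrogen atoms carries a methyl, a chlorine, an amine or a nitrile instead of trifluoromethyl or hydrogen. Also open, on these data alone, is whether the same change behaves like either pair on a pendant ring bearing a methoxy group or a carboxylic acid in place of the hydroxyl groups.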